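This account rests on a few compounds, and the source may have more. Where it says the series, first, only, none or still open, it means among the compounds named here.

In a physicochemical assay for lipophilicity, at pH 7.4 (a lower number here means a more polar compound, a higher number a more lipophilic compound), compound 1 `CNC(=O)c1cc(C(=O)NC2CC2)cn(Cc2nccc3[nH]ccc23)c1=O` gives 1.7, and compound 2 `CNC(=O)c1cc(C(=O)NC2CC2)cn(Cc2cccc3cn[nH]c23)c1=O` gives 2.2, the higher of the two numbers. Compound 3 `CNC(=O)c1cc(C(=O)NC2CC2)cn(CC2CCOCC2)c1=O` has not yet been measured. Its structure departs from that of compound 2 by one exchange, (oxan-4-yl in place of 1H-indazol-7-yl on a saturated chain carbon bound to an aromatic nitrogen), with oxan-4-yl in place of 1H-indazol-7-yl on a saturated chain carbon bound to an aromatic nitrogen. For the measured compounds named here, only one measured step bears on this change: a number 0.50 log units higher from compound 1 to compound 2 (beyond the scatter). That modest step exchanged one aromatic group for another at the same place. Going by the values given here, no measured compound has a non-aromatic ring there, so it guides the size of the new step only loosely. The estimated move is a number 0.90 log units lower from compound 2 to compound 3 (beyond the scatter), which is expected to be downward and larger than the modest step. For compound 3 the expected value in this assay is 1.3, with an estimated range of 0.8 to 1.8.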

Compound 3, distribution coefficient: 1.5
Compound 3: middle estimate off by 0.20 log units, on the low side, within the range that was stated.
By their numbers in this assay, from the lowest: compounds 3 and 1 (each within the scatter of the next); then compound 2.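

In this assay, oxan-4-yl in place of 1H-indazol-7-yl on a saturated chain carbon bound to an aromatic nitrogen brings a number 0.70 log units lower from compound 2 to compound 3 (beyond the scatter) and puts a non-aromatic ring at this place for the only time among these compounds. The comparison with the other aromatic group gives a number 0.20 log units lower from compound 1 to compound 3 (within the scatter) and so shows that the non-aromatic ring is set apart from compound 2 but not from compound 1, which means that leaving the aromatic groups does not by itself decide the number here. Nothing measured here gives a cause for either step.

The compounds shown leave open what an all-carbon cyclohexyl ring would give in place of oxan-4-yl, so the share of the ring oxygen in these steps cannot be separated out. They also leave open how a piperidine ring, which carries an amine, or a carboxylic acid on the same chain carbon would read in this assay.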